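Removing the hydroxy from compound 3

A few compounds are considered here, and "the series" means these few. Any claim that something is new, unique, unknown or untested is made for them only; others in the source may bear on it.

Compound 1, `CC(Sc1nc2c(cnn2C)c(=O)n1-c1ccc(CCO)cc1)c1ccccc1`: 216 nM in an assay on isolated protein for inhibition of retinal dehydrogenase 2 (Homo sapiens); on this read-out higher numbers stand for weaker inhibition and lower numbers for stronger inhibition
Compound 2, `CC(C)C(Sc1nc2c(cnn2C)c(=O)n1-c1ccccc1)c1ccccc1`: 300 nM in this assay
Compound 3, `CC(Sc1nc2c(cnn2C)c(=O)n1-c1ccccc1)c1cccc(O)c1`: 100 nM in this assay

Compound 3 stands lowest of the three numbers. Its nearest neighbour is compound 1, whose number is higher by a margin beyond the scatter, and compound 2 stands further off again, also beyond the scatter. Among the measured compounds shown here, no pair among the three differs in a single place, so no step between measured compounds can be read off; the three values only show that compound 3 sits at the low end.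

Compound 4, `CC(Sc1nc2c(cnn2C)c(=O)n1-c1ccccc1)c1ccccc1`, has not been measured. Relative to compound 3 the change is hydrogen in place of hydroxy on an aromatic carbon, meta to a large group, so that 3-hydroxyphenyl becomes phenyl. For the measured compounds named here, no measured pair isolates this change. The set does show that compound 1 and compound 2, which carry no hydroxy on that ring, give higher numbers in this assay than compound 3, but each also differs from compound 3 elsewhere, so this points to a direction only. The expectation for compound 4 is a modest rise in the number, about a 2.5-fold higher number from compound 3 to compound 4 (0.40 log units; beyond the scatter), at the edge of or just beyond the scatter. Compound 4 is therefore estimated at 250 nM in this assay, with a range of 120 nM to 520 nM.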

Compound 4, half-maximal inhibitory concentration: 110 nM
Compound 4: the middle estimate sits 2.3-fold (0.36 log units) above what was measured; the measured number lies below the stated range.
By their numbers in this assay, from the lowest: compounds 3, 4, 1 and 2 (each within the scatter of the next, the first and the last beyond it).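

In this assay the change from 3-hydroxyphenyl to phenyl gives a 1.1-fold higher number from compound 3 to compound 4 (0.04 log units; within the scatter) and so stays inside the scatter, which means the hydroxy on this aromatic carbon is not required for a number at this level, and the low value of compound 3 cannot be credited to that group. Among the compounds shown here, compound 4 also opens two further single-place comparisons: a 2.7-fold lower number from compound 2 to compound 4 (0.44 log units; beyond the scatter) with methyl in place of isopropyl on the saturated chain carbon, the only one of the three steps beyond the scatter, and a 2.0-fold lower number from compound 1 to compound 4 (0.29 log units; within the scatter) with hydrogen in place of 2-hydroxyethyl on an aromatic carbon, which is within it. No supporting data are available to explain any of these three steps.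

Going by these compounds, whether a methoxy, an amine or a carboxylic acid on the aromatic carbon that carries the hydroxy in compound 3 would also leave the number in place remains open. So does the effect of an ethyl group or a hydrogen in place of the methyl on the saturated chain carbon, as the compounds shown give only methyl and isopropyl there.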